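The source may hold more compounds than are shown below. What is called first, only, known or untested is meant among the compounds shown, and "the series" means these compounds.

Measured compounds:

Compound 1, `Oc1ccc(N2CCN(CC(O)COc3ccc(O)c4ccccc34)CC2)c(O)c1`: in a functional assay on DU-145 cells (Homo sapiens) for antiproliferative activity, read by MTT assay, with a stated time of 48 h (on this read-out higher numbers stand for weaker inhibition and lower numbers for stronger inhibition), compound 1 gives 20300 nM.
Compound 2, `Oc1ccccc1N1CCN(CC(O)COc2cccc3ccccc23)CC1`: in this assay compound 2 gives 18000 nM.
Compound 3, `COc1ccccc1N1CCN(CC(O)COc2ccc(O)c3ccccc23)CC1`: in this assay compound 3 gives 35100 nM.

Among these three numbers compound 1 stands second highest. Its nearest neighbour is compound 2, whose number is slightly lower, and its furthest is compound 3, whose number is higher; both gaps lie within the usual scatter of this measurement, so the three compounds cannot be ranked against one another on this evidence.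

The unmeasured compound 4, `Oc1ccccc1N1CCN(CC(O)COc2ccc(O)c3ccccc23)CC1`, arises from compound 1 by a single change: hydrogen in place of hydroxy on an aromatic carbon.

Among the measured compounds shown here, only one measured step bears on this change. Replacing the 2,4-dihydroxyphenyl group of compound 1 by 2-methoxyphenyl gives a 1.7-fold higher number from compound 1 to compound 3 (0.24 log units; within the scatter), a shift that stays within the scatter. Compound 2 also carries the 2-hydroxyphenyl group found in compound 4, and its value sits close to that of compound 1, though the two differ elsewhere as well. Nothing in the data therefore points to a shift beyond the scatter when the hydroxy is removed, and a step near zero in this assay is expected.

On that basis compound 4 is expected to lie at about 19000 nM, within a range from 9000 nM to 40000 nM. This estimate amounts to an expected step of a 1.1-fold lower number from compound 1 to compound 4 (0.03 log units; within the scatter).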

Compound 4, half-maximal inhibitory concentration: > 50000 nM
Compound 4 was reported as a limit; the forecaster's own chance of this, stated with the estimate: 5%; at least 2.6-fold (0.42 log units) between middle value and limit.
By their numbers in this assay, from the lowest: compounds 2, 1 and 3 (each within the scatter of the next). At a limit, above all of these: compound 4.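

Compound 4 is read in this assay only as a limit of the assay, not as a number: the limit of > 50000 nM in this assay, at which 1 of the 4 values shown sits. Taking away the hydroxy that sits para to a large group, which turns 2,4-dihydroxyphenyl into 2-hydroxyphenyl, gives an at least 2.4-fold higher number from compound 1 to compound 4 (0.39 log units; beyond the scatter), so this carbon matters in a way the earlier step, which stayed within the scatter, did not show. The other hydroxy change gives an at least 2.7-fold higher number from compound 2 to compound 4 (0.44 log units; beyond the scatter), also beyond the scatter, whereas an at least 1.4-fold higher number from compound 3 to compound 4 (0.15 log units; that floor lies within the scatter) has only a floor within the scatter, so compound 3 and compound 4 cannot be ordered.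

From the compounds shown here alone, every step to compound 4 is only a floor, so its true size stays open, and the steps cannot be compared with one another in size. Also open, going by these compounds, is whether an amino group, a fluorine or a methoxy group on this carbon would behave like the hydroxy of compound 1 or like the hydrogen of compound 4.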